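The source may report more compounds than this note shows. Statements on the series, on what has been measured and on what is new or still open speak of the compounds shown alone.

Among the compounds with values here, compound 1 `CCCn1c(=O)c2nc(-c3cnn(Cc4cccc(C)c4)c3)[nH]c2n(CCC)c1=O` and compound 2 `CCCCn1c(=O)c2nc(-c3cnn(Cc4ccccc4)c3)[nH]c2n(CCCC)c1=O` are the two measured members in an in vitro assay on HEK293 cells for displacement of a labelled ligand from adenosine receptor A2b (Homo sapiens); on this read-out lower numbers stand for stronger inhibition and higher numbers for weaker inhibition. In this assay, within the data shown here, compound 1 gives 36 nM, the lower of the two numbers; compound 2 gives 980 nM, and since the two differ in more than one place no single step connects them. Compound 3 `CCCn1c(=O)c2nc(-c3cnn(Cc4cc(Cl)ccc4Cl)c3)[nH]c2n(CCC)c1=O` is not yet measured. It differs from compound 1 by 2,5-dichlorophenyl in place of 3-methylphenyl on a saturated chain carbon bound to an aromatic nitrogen. Among the measured compounds shown here, no measured pair isolates this change, so its direction is open; only a modest step, within or just beyond the scatter, is expected. Compound 3 is therefore estimated at 50 nM, with a range of 12 nM to 200 nM. The expected step is a 1.4-fold higher number from compound 1 to compound 3 (0.14 log units; within the scatter).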

Compound 3, inhibition constant: 29 nM
The estimate for compound 3 lay 1.7-fold (0.24 log units) above the measured number, within the range that was stated.
By their numbers in this assay, from the lowest: compounds 3 and 1 (each within the scatter of the next); then compound 2.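

Placing 2,5-dichlorophenyl in place of 3-methylphenyl on a saturated chain carbon bound to an aromatic nitrogen gives a 1.2-fold lower number from compound 1 to compound 3 (0.09 log units; within the scatter) in this assay. This first single-place comparison in the series shows that this position accepts two chlorine atoms in place of the methyl without a step beyond the scatter. No evidence bearing on this result is at hand. Still open, on these data alone, is whether a phenyl carrying an amine or a carboxylic acid would stay within the scatter of compound 1. As far as these compounds go, the separate contributions of the chain and the benzyl group to the higher number of compound 2 also remain open.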